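The source may hold more compounds than are shown below. What is called first, only, known or untested is meant among the compounds shown, and "the series" means these compounds.

Of the compounds shown here, three built on one shared core have been tested in a functional assay on MDA-MB-231 cells (Homo sapiens) for inhibition, read by MTT assay, with a stated time of 72 h; a lower number here means a stronger inhibitor, a higher number a weaker inhibitor. Compound 1 `O=C(CSc1nc(Nc2ccccc2)c2ccccc2n1)Nc1ccccc1F` carries a 2-fluorophenyl on the amide-type nitrogen; in this assay compound 1 gives only a limit, > 50000 nM, not a number. Compound 2 `O=C(CSc1nc(Nc2ccccc2)c2ccccc2n1)Nc1ccccc1Br` has bromo in place of fluoro on an aromatic carbon, and in this assay compound 2 gives 14100 nM. Compound 3 `COc1cccc(NC(=O)CSc2nc(Nc3ccccc3)c3ccccc3n2)c1` bears a 3-methoxyphenyl on the amide-type nitrogen, and in this assay compound 3 gives 21700 nM, the highest of the two numbers; the step of a 1.5-fold higher number from compound 2 to compound 3 (0.19 log units; within the scatter) stays within the scatter. Compound 4 `O=C(CSc1nc(Nc2ccccc2)c2ccccc2n1)Nc1ccc(Cl)c(Cl)c1` differs from compound 3 by 3,4-dichlorophenyl in place of 3-methoxyphenyl on an amide-type nitrogen. Within the data shown here, two measured steps bear on this: an at least 3.5-fold lower number from compound 1 to compound 2 (0.54 log units; beyond the scatter) and an at least 2.3-fold lower number from compound 1 to compound 3 (0.36 log units; beyond the scatter), both at least modest, while the fluoro compound alone sits at the limit (the limit of > 50000 nM in this assay, at which 1 of the 3 values shown sits). The change to compound 4 brings in two chlorines, halogens like the bromo of compound 2, whose value 14100 nM is close to that of compound 3. Compound 4 is therefore expected to move only a little, a 1.8-fold lower number from compound 3 to compound 4 (0.26 log units; within the scatter), within the scatter. Compound 4 is estimated at 12000 nM, between 4000 nM and 35000 nM.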

Compound 4, half-maximal inhibitory concentration: 14500 nM
Beside the measured number, compound 4's estimate is 1.2-fold (0.08 log units) below it; low and high end bracket the measured number.
By their numbers in this assay, from the lowest: compounds 2, 4 and 3 (each within the scatter of the next). At a limit, above all of these: compound 1.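

In this assay, the change to 3,4-dichlorophenyl gives a 1.5-fold lower number from compound 3 to compound 4 (0.18 log units; within the scatter), and the comparison with the bromo compound gives a 1.0-fold higher number from compound 2 to compound 4 (0.01 log units; within the scatter). The hydrogen-bond acceptor of the 3-methoxyphenyl is therefore not needed to hold the value at this level, and a ring with two chlorines cannot be told apart from the rings of compound 2 and compound 3. The one clear gap still involves the 2-fluorophenyl compound, an at least 3.4-fold lower number from compound 1 to compound 4 (0.53 log units; beyond the scatter), and it rests on a limit rather than a number: the limit of > 50000 nM in this assay, at which 1 of the 4 values shown sits.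

The compounds shown all carry a substituted phenyl on this nitrogen, so it remains open whether an amine or a carboxylic acid on that ring, or a longer chain in its place, would stand clearly apart from these values. From the compounds shown here alone, whether changes to the shared core would do so also remains open.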